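Aryl variation at the amine end of the series

The source may hold more compounds than are shown below. What is called first, only, known or untested is meant among the compounds shown, and "the series" means these compounds.

Measured compounds in a functional assay on MCF7 cells (Homo sapiens) for inhibition, read by MTT assay, with a stated time of 72 h; on this read-out higher numbers stand for weaker inhibition of growth and lower numbers for stronger inhibition of growth:
- compound 1, `O=S(=O)(NCCCNCc1ccc(Cl)cc1)c1cc(C(F)(F)F)cc(C(F)(F)F)c1`: 2400 nM
- compound 2, `COc1cccc(CNCCCNS(=O)(=O)c2cc(C(F)(F)F)cc(C(F)(F)F)c2)c1`: 2400 nM
- compound 3, `O=S(=O)(NCCCNCc1ccc(Cl)c(C(F)(F)F)c1)c1cc(C(F)(F)F)cc(C(F)(F)F)c1`: 3500 nM

On these numbers compound 3 gives the highest value of the three, but its gap to each neighbour is small: a 1.5-fold higher number from compound 1 to compound 3 (0.16 log units; within the scatter) and a 1.5-fold higher number from compound 2 to compound 3 (0.16 log units; within the scatter), both within the scatter, as is no change at the digits printed from compound 1 to compound 2 (within the scatter). Across the three aryl groups tried on the saturated chain carbon bound to the amine nitrogen, this assay has so far shown no separation.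

Compound 4, `O=S(=O)(NCCCNCc1ccccc1)c1cc(C(F)(F)F)cc(C(F)(F)F)c1`, has not been measured. It differs from compound 3 as follows: phenyl in place of 4-chloro-3-(trifluoromethyl)phenyl on a saturated chain carbon bound to an amine nitrogen. For the measured compounds named here, the steps that bear on it are the aryl swaps already made: compound 1 to compound 3 adds a trifluoromethyl and moves the number only within the scatter, and compound 2 to compound 3 likewise. Removing both the chlorine and the trifluoromethyl to give a bare phenyl is therefore expected to stay within the scatter, with no direction beyond it: the expected step is a 1.3-fold lower number from compound 3 to compound 4 (0.10 log units; within the scatter). For compound 4 the estimate in this assay is 2800 nM, within 1200 nM to 7000 nM.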

Compound 4, concentration for 50% growth inhibition: 3000 nM
The estimate for compound 4 lay 1.1-fold (0.03 log units) below the measured number; measured number inside the range.
By their numbers in this assay, from the lowest: compounds 1, 2, 4 and 3 (each within the scatter of the next).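

With a 1.2-fold lower number from compound 3 to compound 4 (0.07 log units; within the scatter) in this assay as the step, the full exchange of 4-chloro-3-(trifluoromethyl)phenyl, with 11 heavy atoms, for phenyl, with 6, stays within the scatter. The single removals read the same, with a 1.3-fold higher number from compound 2 to compound 4 (0.10 log units; within the scatter) for methoxy and a 1.3-fold higher number from compound 1 to compound 4 (0.10 log units; within the scatter) for chloro, so the unsubstituted phenyl now joins the substituted rings without separation, and none of the three substituents tried on this aromatic ring is needed to hold the number at this level. Nothing measured here speaks to why these changes leave the number in place.

Still open, as far as these compounds go, is whether a non-aryl group such as cyclohexyl, or a pyridine ring, on the saturated chain carbon bound to the amine nitrogen would move the number. From the compounds shown here alone, a carboxylic acid on the phenyl or a longer chain in the shared core also remains untested in these data.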